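A few compounds are considered here, and "the series" means these few. Any claim that something is new, unique, unknown or untested is made for them only; others in the source may bear on it.

Series notes. Among the measured compounds shown here, compound 1 `COc1ccccc1-n1nc(C2CC(C)(C)OC(C)(C)C2)cc1-c1ccnc(Cl)c1` carries a 2-chloropyridin-4-yl group on the shared core and in an assay on HEK293 cells for inhibition of Voltage-dependent N-type calcium channel subunit alpha-1B (Homo sapiens), read by patch clamp, using a membrane potential dye (on this read-out higher numbers stand for weaker inhibition and lower numbers for stronger inhibition), compound 1 gives 740 nM, the highest of the three numbers so far. For the measured compounds named here, compound 2 `COc1ccccc1-n1nc([C@H]2C[C@@H](C)O[C@@H](C)C2)cc1-c1ccc(Cl)cc1` gives 91 nM and compound 3 `COc1ccccc1-n1nc(C2CCOC(C)(C)C2)cc1-c1ccc(Cl)cc1` gives 150 nM; the one measured step, a 1.6-fold higher number from compound 2 to compound 3 (0.22 log units; within the scatter), concerns only the oxane and not the aryl ring, so it does not bear on the change considered here. The gap from compound 1 to compound 3 and to compound 2 lies beyond the scatter, but those two compounds differ from compound 1 in more than one place, so nothing can be read from them about the aryl ring alone.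

Compound 4 `COc1ccccc1-n1nc(C2CC(C)(C)OC(C)(C)C2)cc1-c1csc(Cl)c1` differs from compound 1 as follows: 5-chlorothiophen-3-yl in place of 2-chloropyridin-4-yl on an aromatic carbon. Going by the values given here, no measured step touches an exchange of this kind, so no step beyond the scatter is expected; the number for compound 4 is estimated close to that of compound 1, an expected step of a 1.5-fold lower number from compound 1 to compound 4 (0.17 log units; within the scatter). The estimate for compound 4 is 500 nM, with a range from 150 nM to 1600 nM.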

Compound 4, half-maximal inhibitory concentration: 62 nM
Compound 4: middle estimate off by 8.1-fold (0.91 log units), on the high side, and the stated range ends above it.
By their numbers in this assay, from the lowest: compounds 4, 2 and 3 (each within the scatter of the next, the first and the last beyond it); then compound 1.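

In this assay, among the compounds shown here, the position on an aromatic carbon next to the ring nitrogen proves sensitive to the aryl group: with the 2,2,6,6-tetramethyloxan-4-yl and 2-methoxyphenyl groups unchanged, 5-chlorothiophen-3-yl in place of 2-chloropyridin-4-yl gives a 12-fold lower number from compound 1 to compound 4 (1.08 log units; beyond the scatter) and this is the first measured step at this position. The exchange alters ring size and hetero atom together, so the step belongs to the pair of groups as a whole and not to either alteration alone. Nothing measured here accounts for the size of this step.

The compounds shown do not separate the thiophene ring from its chlorine, so how a methyl group or a nitrile in place of that chlorine would read stays open. Also open, on these data alone, is whether the same exchange gives a step of similar size with the 2,2-dimethyloxan-4-yl group in place of the 2,2,6,6-tetramethyloxan-4-yl group.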